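The compounds below may be only part of what the source reports. "The series", "measured", "known", "first", "only" and "open" are said of these compounds alone.

Measured compounds:
compound 1, `O=c1ccc2cc(OCc3cc(-c4ccc5ccccc5c4)no3)ccc2o1` — 48700 nM
compound 2, `COc1cccc(-c2cc(COc3ccc4oc(=O)ccc4c3)on2)c1` — "not determined" (no result reported)

In a functional assay on COLO 205 cells (Homo sapiens) for cytotoxicity, read by MTT assay, with a stated time of 48 h (a lower number here means a stronger inhibitor, a higher number a weaker inhibitor), compound 1 gives 48700 nM, a weak result. Compound 2 belongs to the same series, but in this assay compound 2 gives "not determined" (no result reported), so no number stands against it and where it sits among the measured compounds cannot be said. The step to compound 3, `O=c1ccc2cc(OCc3cc(-c4ccc([N+](=O)[O-])cc4)no3)ccc2o1`, is a single change: 4-nitrophenyl in place of 3-methoxyphenyl on an aromatic carbon. Within the data shown here, with no number for compound 2 and no step between measured compounds, the size and direction of this change in this assay cannot be read from the data; the only anchor is the weak result of compound 1. Compound 3 is therefore expected to stay a weak inhibitor, with no shift beyond the scatter anticipated in either direction. The estimate for compound 3 in this assay is 35000 nM, within a range from 8000 nM to 120000 nM.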

Compound 3, half-maximal inhibitory concentration: 47800 nM
Estimate against measurement, compound 3: 1.4-fold (0.14 log units) below; the range from low to high includes it.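

No new step can be read from the result for compound 3, as compound 2 has no value to set against it in this assay. Nothing shown bears on a cause for this result. The compounds shown leave open how the 3-methoxyphenyl and 4-nitrophenyl groups compare in this assay.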